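Swapping the formyl for aminomethyl on compound 3

This account rests on a few compounds, and the source may have more. Where it says the series, first, only, none or still open, it means among the compounds named here.

Among the measured compounds shown here, compound 3 `O=Cc1cc2cc(Br)ccc2o1` stands at the top of the three numbers so far: in an assay on isolated protein for inhibition of cytochrome P450 2A6 (Homo sapiens), read by fluorescence, with a stated time of 10 min (on this read-out lower numbers stand for stronger inhibition and higher numbers for weaker inhibition), compound 3 gives 72000 nM, the weakest inhibition seen. Compound 2 `Cn1ccc2ccc(C=O)cc21` gives 8400 nM in this assay, and compound 1 `CN(C)Cc1cc2cnccc2s1` gives 1400 nM, both clearly lower. The next compound, compound 4 `NCc1cc2cc(Br)ccc2o1`, keeps the core of compound 3 and differs in one place: aminomethyl in place of formyl on an aromatic carbon. For the measured compounds named here, no measured pair shows this same swap, so its size is uncertain; since compound 1, whose side chain also ends in a nitrogen, gives 1400 nM, a move towards stronger inhibition seems more likely than the reverse, though a step within the scatter cannot be ruled out. The step expected in this assay is a 3.6-fold lower number from compound 3 to compound 4 (0.56 log units; beyond the scatter). Compound 4 is estimated at 20000 nM, with a range from 5000 nM to 72000 nM.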

Compound 4, half-maximal inhibitory concentration: < 100000 nM
Compound 4 was reported as a limit; the forecaster's own chance of this, stated with the estimate: 5%; the middle value lies beyond the limit too.
By their numbers in this assay, from the lowest: compound 1; then compound 2; then compound 3.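

Among the compounds shown here, no step from compound 3 to compound 4 can be read, because compound 4 is reported only as a limit: the limit of < 100000 nM in this assay, at which 1 of the 4 values shown sits. The compounds shown leave open whether aminomethyl in place of formyl on an aromatic carbon strengthens or weakens inhibition, and by how much.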